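Benzofuran for furan on the shared nucleoside core

The source may report more compounds than this note shows. Statements on the series, on what has been measured and on what is new or still open speak of the compounds shown alone.

Compound 1 `O=c1[nH]cnc2c1c(-c1ccoc1)cn2[C@@H]1O[C@H](CO)[C@@H](O)[C@H]1O` is known in an ADME assay on BJ cells (Homo sapiens), read by MTT assay, with a stated time of 72 h (on this read-out higher numbers stand for weaker inhibition and lower numbers for stronger inhibition), only as a limit: compound 1 gives > 100000 nM, which means compound 1 stands at the limit of > 100000 nM in this assay, at which 1 of the 2 values shown sits, and carries no number of its own. Going by the values given here, compound 2 `Nc1nc2c(c(-c3ccoc3)cn2[C@@H]2O[C@H](CO)[C@@H](O)[C@H]2O)c(=O)[nH]1` gives 21500 nM in this assay; the step of an at least 4.6-fold lower number from compound 1 to compound 2 (0.66 log units; beyond the scatter) is the only measured step in the set. Compound 3 `O=c1[nH]cnc2c1c(-c1cc3ccccc3o1)cn2[C@@H]1O[C@H](CO)[C@@H](O)[C@H]1O` differs from compound 1 by 1-benzofuran-2-yl in place of furan-3-yl on an aromatic carbon. Among the compounds with values here, the one measured step concerns another change, amino in place of hydrogen on an aromatic carbon, and so gives no guide to the size of the present one; the set holds no pair that exchanges furan-3-yl for 1-benzofuran-2-yl. Given that, the expected step is an at least 1.4-fold lower number from compound 1 to compound 3 (0.15 log units; that floor lies within the scatter), with a fair chance that compound 3 again returns only a limit. Compound 3 is estimated at 70000 nM, with a range from 15000 nM to 100000 nM.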

Compound 3, half-maximal inhibitory concentration: 62700 nM
Compound 3: middle estimate off by 1.1-fold (0.05 log units), on the high side; low and high end bracket the measured number.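

In this assay, the aromatic carbon that carries furan-3-yl in compound 1 also accepts 1-benzofuran-2-yl, with its added six-membered aromatic ring of carbon only, and compound 3 gives a measured value of 62700 nM. This change gives an at least 1.5-fold lower number from compound 1 to compound 3 (0.20 log units; that floor lies within the scatter), so the data do not establish a real gain for the larger group, though they do not exclude one. The step is only a floor, with compound 1 held at a limit and not a number: the limit of > 100000 nM in this assay, at which 1 of the 3 values shown sits.

Going by these compounds, it remains open how the amino group of compound 2 and the 1-benzofuran-2-yl group of compound 3 would behave together on the shared core. Also open, on these data alone, is how an amine or a carboxylic acid on the same aromatic carbon would shift the number.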